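Anilide series: loss of one methyl on the aryl group

This account rests on a few compounds, and the source may have more. Where it says the series, first, only, none or still open, it means among the compounds named here.

Values in an assay on isolated protein for inhibition of high affinity 3',5'-cyclic-AMP phosphodiesterase 7A (Homo sapiens), read by cAMP accumulation, with a stated time of 10 min; a lower number here means a stronger inhibitor, a higher number a weaker inhibitor:
- compound 1, `COc1nc2c(c(=O)n(C)c(=O)n2C)n1CC(=O)Nc1ccc(C(C)(C)C)cc1`: > 200000 nM (a limit)
- compound 2, `CCOc1nc2c(c(=O)n(C)c(=O)n2C)n1CC(=O)Nc1ccc(C(C)(C)C)cc1`: > 200000 nM (a limit)
- compound 3, `CCCOc1nc2c(c(=O)n(C)c(=O)n2C)n1CCCC(=O)Nc1ccc(C(C)(C)C)cc1`: 7760 nM

In this assay compound 1 returns only a limit, > 200000 nM. Compound 2 likewise gives only a limit in this assay, > 200000 nM. Going by the values given here, compound 3 is the single compound with a real number, 7760 nM. The difference between the cores of compound 2 and compound 3 is not broken down here.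

From compound 2 to compound 1 the change is hydrogen in place of methyl on a saturated chain carbon bound to an oxygen on an aromatic ring; the step that the two limits leave unreadable from compound 2 to compound 1 cannot be read because of the limit of > 200000 nM in this assay, at which 2 of the 3 values shown sit. From compound 3 to compound 4, `CCCOc1nc2c(c(=O)n(C)c(=O)n2C)n1CCCC(=O)Nc1ccc(C(C)C)cc1`, the change is hydrogen in place of methyl on a saturated chain carbon bound to an aromatic carbon and two saturated chain carbons. Among the compounds with values here, this is the same kind of change as the one from compound 2 to compound 1, not the same: there the place is a saturated chain carbon bound to an oxygen on an aromatic ring, here it is a saturated chain carbon bound to an aromatic carbon and two saturated chain carbons. The earlier step thus gives no usable size for the new one, and the expectation rests on compound 3 alone, 7760 nM, with a small loss allowed for removing one methyl from the aryl group. The step from compound 3 to compound 4 is expected to be a 1.9-fold higher number from compound 3 to compound 4 (0.29 log units; within the scatter). For compound 4 in this assay the estimate is 15000 nM, expected to lie between 4000 nM and 60000 nM.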

Compound 4, half-maximal inhibitory concentration: 37600 nM
Beside the measured number, compound 4's estimate is 2.5-fold (0.40 log units) below it; the measured number falls inside the stated range.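

In this assay, cutting tert-butyl to isopropyl on the core shared by compound 3 and compound 4 gives a 4.8-fold higher number from compound 3 to compound 4 (0.69 log units; beyond the scatter), so on this core the 4-(tert-butyl)phenyl group does better than the 4-isopropylphenyl group, and compound 4 still returns a real number, 37600 nM. This is one pair on one core, and it gives a size for that core only; nothing shown tests whether the same change has the same size, or even the same direction, on the core of compound 1 or compound 2, which differs from that of compound 3 in more than one place. The single step available on that other core is a different change, on a saturated chain carbon bound to an oxygen on an aromatic ring, and it cannot be read because both of its compounds return only a limit: the limit of > 200000 nM in this assay, at which 2 of the 4 values shown sit.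

Still open, going by these compounds, is how the number moves with other groups in place of tert-butyl, such as cyclopropyl or trifluoromethyl, or with a carboxylic acid or an amine at that place. Also open, on these data alone, is how much of the gap between the cores of compound 2 and compound 3 belongs to the chain on the oxygen and how much to the chain leading to the amide.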